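This account rests on a few compounds, and the source may have more. Where it says the series, first, only, none or still open, it means among the compounds named here.

Compounds measured so far in a functional assay on EC9706 cells (Homo sapiens) for cytotoxicity, read by MTT assay, with a stated time of 72 h; a higher number here means a weaker inhibitor, a lower number a stronger inhibitor:
compound 1, `CC(=O)c1ccc(NC(=O)CSC(=S)N[C@H]2CCOC2=O)cc1`
compound 2, `CCOC(=O)c1ccc(NC(=O)CSC(=S)N[C@H]2CCOC2=O)cc1`
compound 3, `O=C(CCl)Nc1ccc(C(=O)/C=C/c2ccc(Cl)cc2)cc1`

Compound 1 reaches only the limit of this assay, > 128000 nM. Compound 2 gives 112000 nM, and compound 3 gives 8340 nM. Going by the values given here, the one single-point step among the measured pairs is an at least 1.1-fold lower number from compound 1 to compound 2 (0.05 log units; that floor lies within the scatter), which is on the acetyl side chain and does not touch the part changed here. Compound 3 stands with the lowest of the two numbers reported; the nearest number is that of compound 2, which sits well above it, beyond the scatter, while the value of compound 1 is a limit of > 128000 nM in this assay, at which 1 of the 3 values shown sits, and gives no number.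

Compound 4, `O=C(CSC(=S)N[C@H]1CCOC1=O)Nc1ccc(C(=O)/C=C/c2ccc(Cl)cc2)cc1`, differs from compound 3 by a group of 10 heavy atoms (5 carbon, 1 nitrogen, 2 oxygen, 2 sulfur; one five-membered non-aromatic ring with 1 hetero atom) in place of one chlorine atom, on a saturated chain carbon bound to a carbonyl carbon. Among the compounds with values here, no measured step covers this change. From the compounds shown here alone, compounds 1 and 2, which carry the same entering group on an amide without the enone of compound 3, both lie far above compound 3, so the chalcone amide of compound 3 appears to be what carries the lower number there; whether the larger tail on the carbonyl-bound carbon costs anything is unknown. The expected step is a 1.8-fold higher number from compound 3 to compound 4 (0.25 log units; within the scatter), with a wide range. Compound 4 is estimated at 15000 nM in this assay, between 4000 nM and 60000 nM.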

Compound 4, half-maximal inhibitory concentration: 38900 nM
Compound 4: middle estimate off by 2.6-fold (0.41 log units), on the low side; the range from low to high includes it.
By their numbers in this assay, from the lowest: compound 3; then compound 4; then compound 2. At a limit, above all of these: compound 1.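

Within this assay, this position on the saturated chain carbon bound to a carbonyl carbon does respond to the change: the group of 10 heavy atoms in place of chloro gives a 4.7-fold higher number from compound 3 to compound 4 (0.67 log units; beyond the scatter), so the tail carried by compounds 1 and 2 does not preserve the lower number of compound 3. With that tail held constant, 2-(4-chlorophenyl)ethenyl on the carbonyl carbon gives a 2.9-fold lower number from compound 2 to compound 4 (0.46 log units; beyond the scatter) and an at least 3.2-fold lower number from compound 1 to compound 4 (0.51 log units; beyond the scatter), so this group lowers the number in the tail-bearing compounds as well, although compound 4 still stays above compound 3. The step from the acetyl compound gives only a floor for the size of the change, as compound 1 stands at a limit and has no number: the limit of > 128000 nM in this assay, at which 1 of the 4 values shown sits.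

From the compounds shown here alone, what remains open is which feature of the entering group raises the number, since the ring, the sulfur-bearing link and the overall size all enter together; a dimethylamino group, a simple propyl chain or a carboxylic acid in place of chlorine on that carbon would help to separate them. Going by these compounds, the role of the chlorine on the phenyl ring is also open, and a methoxy group or plain hydrogen there would test it.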